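The compounds below may be only part of what the source reports. "The series", "measured", "known", "first", "only" and "open" are said of these compounds alone.

Compound 1, whose structure is `O=C(Nc1ccc(Cl)cc1)Nc1cccc(CNc2nccnc2Cl)c1`, stands lowest of the three numbers recorded in a functional assay on MGC-803 cells (Homo sapiens) for antiproliferative activity, read by MTT assay, with a stated time of 48 h (on this read-out lower numbers stand for stronger inhibition and higher numbers for weaker inhibition), where compound 1 gives 4980 nM. Its nearest neighbour is compound 3, structure `Cc1ccc(NC(=O)Nc2cccc(CNc3nccnc3Cl)c2)cc1`, which in this assay gives 11900 nM; the furthest is compound 2, structure `O=C(Nc1cccc(CNc2nccnc2Cl)c1)Nc1cccc2ccccc12`, which gives 32700 nM. The one single-point step among these, a 2.4-fold higher number from compound 1 to compound 3 (0.38 log units; beyond the scatter), concerns methyl in place of chloro on an aromatic carbon, a different change from the one now in question. Compound 4, structure `O=C(Nc1cccc(CNc2nccnc2Cl)c1)Nc1ccc(Cl)cc1Br`, differs from compound 1 in that (bromo in place of hydrogen on an aromatic carbon). Among the measured compounds shown here, no measured pair shows bromo entering in place of hydrogen, so nothing here speaks directly to the direction of this step; the only comparable substituent changes are modest or within the scatter, and a small effect is the reasonable expectation. The estimate for compound 4 in this assay is therefore 4500 nM, with a range from 1500 nM to 13500 nM, meaning an expected step of a 1.1-fold lower number from compound 1 to compound 4 (0.04 log units; within the scatter).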

Compound 4, half-maximal inhibitory concentration: 7480 nM
Compound 4: the middle estimate sits 1.7-fold (0.22 log units) below what was measured; the range from low to high includes it.
By their numbers in this assay, from the lowest: compounds 1, 4 and 3 (each within the scatter of the next, the first and the last beyond it); then compound 2.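

In this assay, bromo in place of hydrogen on an aromatic carbon, ortho to a large group and meta to a chloro group, gives a step within the scatter (a 1.5-fold higher number from compound 1 to compound 4 (0.18 log units; within the scatter)), so this position accepts the added bromine without a clear change in the read-out. The step for 2-bromo-4-chlorophenyl in place of 4-methylphenyl (a 1.6-fold lower number from compound 3 to compound 4 (0.20 log units; within the scatter)) is also within the scatter, which leaves compound 4 unresolved from both neighbours even though the step between those two (a 2.4-fold higher number from compound 1 to compound 3 (0.38 log units; beyond the scatter)) lies beyond it. Nothing available explains these small steps.

The compounds shown leave open whether an amine, a carboxylic acid or a methoxy group on this same carbon would behave like bromo. They also leave open what bromo would do here with methyl in place of the chloro group.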